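Fluoro in place of hydrogen: compound 3 to compound 4

The source may report more compounds than this note shows. Statements on the series, on what has been measured and on what is new or still open speak of the compounds shown alone.

Measured compounds:
compound 1 `O=S(=O)(CC1CC1)c1nnc(-c2cc(F)c(-c3cnc(Oc4ccccc4C(F)(F)F)c(Cl)c3)cc2F)[nH]1` — < 14 uL/min
compound 2 `O=S(=O)(CC1CC1)c1nnc(-c2cc(F)c(-c3cnc(Oc4ccc(F)cc4Cl)c(Cl)c3)cc2F)[nH]1` — < 14 uL/min
compound 3 `CC(C)COc1ncc(-c2ccc(-c3nnc(S(=O)(=O)C4CCC4)[nH]3)cc2F)cc1Cl` — 93 uL/min

Within the data shown here, in an ADME assay on microsomes from liver (Homo sapiens) for metabolic stability (on this read-out higher numbers stand for fast clearance and lower numbers for slow clearance), compound 3 gives 93 uL/min, the only value in the set that is a number rather than a limit. The value of compound 1 is a limit of this assay, < 14 uL/min. The value of compound 2 is likewise a limit, < 14 uL/min. Among the measured compounds shown here, the one step between measured compounds, a step that the two limits leave unreadable from compound 1 to compound 2, therefore has no readable size, since both ends sit at the limit of < 14 uL/min in this assay, at which 2 of the 3 values shown sit.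

Compound 4 `CC(C)COc1ncc(-c2cc(F)c(-c3nnc(S(=O)(=O)C4CCC4)[nH]3)cc2F)cc1Cl` differs from compound 3 by fluoro in place of hydrogen on an aromatic carbon. For the measured compounds named here, no measured step concerns this change; compounds 1 and 2 show only that two members clear slowly in this assay, and neither differs from compound 3 in one place alone. No step beyond the usual scatter is expected from the change. Compound 4 is therefore estimated at 70 uL/min, within a range of 30 uL/min to 150 uL/min. The step of a 1.3-fold lower number from compound 3 to compound 4 (0.12 log units; within the scatter) that this estimate implies is expected to stay within the scatter, with some chance that only a limit is reported.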

Compound 4, intrinsic clearance in a liver preparation (reported as CLH), per the amount of preparation that the assay uses: 53 uL/min
The estimate for compound 4 lay 1.3-fold (0.12 log units) above the measured number, and the stated range covers the measured number.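

In this assay, fluoro in place of hydrogen on an aromatic carbon, ortho to a large group, meta to a large group and para to a fluoro group, gives a 1.8-fold lower number from compound 3 to compound 4 (0.24 log units; within the scatter). Among these compounds, this is the only readable step, and it shows that this change at this position leaves the two numbers within the scatter of each other. The step between compound 1 and compound 2 cannot be read, as each compound carries a limit and not a number: the limit of < 14 uL/min in this assay, at which 2 of the 4 values shown sit.

Open, from the compounds shown here alone, is whether an amine or a nitrile on this aromatic carbon would give a step beyond the scatter in this assay. Among the compounds shown here, also open is whether fluoro in place of hydrogen at this position gives a similar step with a group other than the one shared by compound 3 and compound 4 on the shared core.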